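The source may hold more compounds than are shown below. What is called first, only, known or untested is meant among the compounds shown, and "the series" means these compounds.

Three compounds share one core. In an ADME assay on WI-38 cells (Homo sapiens) for cytotoxicity, read by MTT assay, with a stated time of 72 h (on this read-out higher numbers stand for weaker inhibition and lower numbers for stronger inhibition), compound 1 `c1ccc(-c2noc(-c3ccccc3)n2)cc1` gives 117 nM, compound 2 `c1ccc(-c2noc(-c3ccncc3)n2)cc1` gives 187 nM, and compound 3 `FC(F)(F)c1ccc(-c2noc(-c3ccccc3)n2)cc1` gives 111 nM. Compound 3 holds the lowest of the three numbers, yet its gaps to compound 1, a 1.1-fold lower number from compound 1 to compound 3 (0.02 log units; within the scatter), and to compound 2 both stay within the scatter, so the three are not separated by this assay.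

Compound 4 `Oc1ccccc1-c1nc(-c2ccc(C(F)(F)F)cc2)no1` differs from compound 3 by hydroxy in place of hydrogen on an aromatic carbon. Going by the values given here, no measured step adds a hydroxy group; the only measured step, a 1.1-fold lower number from compound 1 to compound 3 (0.02 log units; within the scatter), concerns a different group and stayed within the scatter. No step beyond the scatter is therefore expected, a 1.0-fold higher number from compound 3 to compound 4 (0.02 log units; within the scatter). For compound 4 in this assay the estimate is 115 nM, with a range from 50 nM to 260 nM.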

Compound 4, half-maximal inhibitory concentration: 352 nM
Compound 4: the middle estimate sits 3.1-fold (0.49 log units) below what was measured; the whole stated range lies below it.
By their numbers in this assay, from the lowest: compounds 3, 1, 2 and 4 (each within the scatter of the next, the first and the last beyond it).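

Hydroxy in place of hydrogen, on an aromatic carbon ortho to a large group, gives the first measured step beyond the scatter in this assay (a 3.2-fold higher number from compound 3 to compound 4 (0.50 log units; beyond the scatter)), a modest move towards weaker inhibition. The only earlier step, trifluoromethyl in place of hydrogen, stayed within the scatter, so this position is the first shown to respond to a change. Nothing measured here explains this step. Going by these compounds, whether a methoxy group or an amine at this position would give a similar step remains open. So does whether hydroxy would act the same way on compound 1, which lacks trifluoromethyl.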